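Nitro for Chloro on Two Related Cores

The source may hold more compounds than are shown below. What is called first, only, known or untested is meant among the compounds shown, and "the series" means these compounds.

Compound 1, `COc1cc(OC)c(/C=C/S(=O)(=O)Cc2ccc(Cl)cc2)c(OC)c1`, gives 10000 nM in a functional assay on BT-20 cells (Homo sapiens) for antiproliferative activity, read by trypan blue exclusion; on this read-out lower numbers stand for stronger inhibition and higher numbers for weaker inhibition.
Compound 2, `COc1cc(OC)c(/C=C/S(=O)(=O)Cc2ccc([N+](=O)[O-])cc2)c(OC)c1`, gives 15000 nM in this assay.
Compound 3, `COc1ccc(CS(=O)(=O)/C=C/c2ccc(Cl)cc2)cc1`, gives 2000 nM in this assay.

Compound 3 stands lowest of the three, and its distance from compound 1 and from compound 2 lies beyond the scatter. The difference between the core of compound 1 and the core of compound 3 is not broken down here. Compound 4, `COc1ccc(CS(=O)(=O)/C=C/c2ccc([N+](=O)[O-])cc2)cc1`, carries nitro in place of chloro on an aromatic carbon relative to compound 3. The same change, (nitro in place of chloro on an aromatic carbon), has already been made once: a 1.5-fold higher number from compound 1 to compound 2 (0.18 log units; within the scatter). Since the place is the same in both pairs, compound 4 is expected to follow compound 3 by a similarly small step, a 1.4-fold higher number from compound 3 to compound 4 (0.15 log units; within the scatter), because a 1.5-fold higher number from compound 1 to compound 2 (0.18 log units; within the scatter) stayed within the scatter. Compound 4 is therefore estimated at 2800 nM, with a likely range of 1200 nM to 6500 nM.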

Compound 4, half-maximal inhibitory concentration: 5000 nM
The estimate for compound 4 lay 1.8-fold (0.25 log units) below the measured number, and the stated range covers the measured number.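

In this assay, nitro in place of chloro on the core of compound 3 gives a 2.5-fold higher number from compound 3 to compound 4 (0.40 log units; beyond the scatter) as a modest step that lies beyond the scatter. Set beside the step on the core of compound 1, it shows no difference larger than two such steps would scatter, so the change carried from one core to the other without a detectable difference: the same change on two cores in this assay, a 1.5-fold higher number (0.18 log units; within the scatter) from compound 1 to compound 2 and a 2.5-fold higher number (0.40 log units; beyond the scatter) from compound 3 to compound 4, 1.7-fold (0.22 log units) apart, within the scatter of two such steps. Among these compounds, this rests on only two pairs and does not show that the change would behave alike on any other core.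

The compounds shown leave open what other groups at this place, such as an amine or a carboxylic acid, would do to the number. They also leave open what the core alone contributes: no pair shown changes only the core.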